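Chloro in place of ethoxy on the outer aromatic ring

The source may hold more compounds than are shown below. What is called first, only, known or untested is meant among the compounds shown, and "the series" means these compounds.

Compound 3 `CCOC(=O)CCCCCOc1cccc(CN(C(=O)c2ccc(-c3cccc(OCC)c3)cc2)C(C)C)c1` was examined in an ADME assay on HEK293 cells (Homo sapiens) for cytotoxicity, read by CellTiter-Glo and resazurin assay, with a stated time of 72 h; a lower number here means that less compound is needed, a higher number that more compound is needed for the effect. In this assay compound 3 gives only a limit of the assay, > 22300 nM. Compound 3 thus sits at the limit of > 22300 nM in this assay, at which 1 of the 3 values shown sits. Compound 1 `CCOC(=O)CCCCCOc1cccc(CN(C(=O)c2ccc(-c3ccc(C(C)=O)s3)cc2)C(C)C)c1` likewise gives only a limit in this assay, > 26000 nM. Compound 2 `CCOC(=O)CCCCCOc1cccc(CN(C(=O)c2ccc(-c3cccc(OC)c3)cc2)C(C)C)c1` also gives only a limit in this assay, > 21000 nM. Compound 4 `CCOC(=O)CCCCCOc1cccc(CN(C(=O)c2ccc(-c3cccc(Cl)c3)cc2)C(C)C)c1` has not yet been measured; it differs from compound 3 by chloro in place of ethoxy on an aromatic carbon. Going by the values given here, the steps that bear on this, a step that the two limits leave unreadable from compound 2 to compound 3, a step that the two limits leave unreadable from compound 1 to compound 3 and a step that the two limits leave unreadable from compound 1 to compound 2, each join two limits and so carry no readable size or direction. With no readable step among the measured compounds, compound 4 is expected to remain at or beyond the limit, the expected step being a step that the limit leaves unreadable from compound 3 to compound 4. Compound 4 is estimated at 30000 nM, within 12000 nM to 80000 nM.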

Compound 4, half-maximal effective concentration: > 18400 nM
Compound 4 ended at the assay's limit; the forecaster's own chance of this, stated with the estimate: 80%; the middle value lies beyond the limit too.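

Going by these compounds alone, compound 4 gives only a limit in this assay, as do compound 1, compound 2 and compound 3, so no step between them can be read. The compounds shown leave open what concentration would reach the half-maximal effect for any of them.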